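Ethynyl for bromo on the aryl core of compound 1

The source may hold more compounds than are shown below. What is called first, only, known or untested is meant among the compounds shown, and "the series" means these compounds.

Measured compounds:
compound 1, `COc1ccc(-c2ccc(C(=O)N[C@H](C)CCCc3cccnc3)cc2Br)cc1OC`, in an assay (Canis lupus familiaris) for binding affinity to platelet-activating factor receptor (Homo sapiens), read by radioligand binding (on this read-out higher numbers stand for weaker inhibition and lower numbers for stronger inhibition), compound 1 gives 180 nM.
compound 2, `COc1ccc(-c2ccc(C(=O)NCCCCc3cccnc3)cc2Br)cc1OC`, compound 2 gives 220 nM.
compound 3, `O=C(NCCCCc1cccnc1)c1ccc(-c2cccc(O)c2)cc1`, compound 3 gives 300 nM.

The three numbers sit close together. Among the measured compounds shown here, the only single-point step among them, a 1.2-fold higher number from compound 1 to compound 2 (0.09 log units; within the scatter), stays within the scatter, and the gap from compound 1 to compound 3 does too, so compound 1 cannot be set apart from either of the other two on these numbers.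

Compound 4, `C#Cc1cc(C(=O)N[C@H](C)CCCc2cccnc2)ccc1-c1ccc(OC)c(OC)c1`, differs from compound 1 in one place: ethynyl in place of bromo on an aromatic carbon. For the measured compounds named here, no measured pair shows a change on this aromatic carbon, and the one measured step concerns the saturated chain at the amide nitrogen, not this ring, so nothing here speaks directly to the size or direction of the step. With no bearing step beyond the scatter, the number for compound 4 in this assay is expected to stay near that of compound 1, and the step of a 1.1-fold higher number from compound 1 to compound 4 (0.05 log units; within the scatter) is estimated to lie within the scatter. Compound 4 is therefore expected to give about 200 nM, between 70 nM and 600 nM.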

Compound 4, half-maximal inhibitory concentration: 5 nM
Compound 4: middle estimate off by 40-fold (1.60 log units), on the high side; the measured number lies below the stated range.
By their numbers in this assay, from the lowest: compound 4; then compounds 1, 2 and 3 (each within the scatter of the next).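

In this assay, among the compounds shown here, the aromatic carbon ortho to a 3,4-dimethoxyphenyl group turns out to be highly sensitive to what it carries: ethynyl in place of bromo gives a step beyond the scatter (a 36-fold lower number from compound 1 to compound 4 (1.56 log units; beyond the scatter)), whereas the only earlier single-point step, at the saturated chain (a 1.2-fold higher number from compound 1 to compound 2 (0.09 log units; within the scatter)), stayed within it. The earlier compounds shown here showed no change on this carbon, and this swap of one bromine atom for two carbon atoms and a triple bond, with no hydrogen-bond donor or acceptor on either group, sets compound 4 apart from compounds 1, 2 and 3. No evidence is available on why this change has so large an effect.

The compounds shown leave open how a nitrile, a propynyl group or a plain hydrogen on this carbon would compare with ethynyl. They also leave open whether ethynyl would give a step of this size on the chain of compound 2.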